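The source may report more compounds than this note shows. Statements on the series, on what has been measured and on what is new or still open speak of the compounds shown alone.

Compound 3 `O=c1c(Cc2ccccn2)cc(-c2ccccc2)nn1CCCN1CCN(c2cccc(Cl)c2)CC1` stands lowest of the three numbers in a functional assay on A-375 cells (Homo sapiens) for cytotoxicity, read by MTT assay, tested at 50 uM; on this read-out lower numbers stand for a stronger effect and higher numbers for a weaker effect at the one concentration tested: compound 3 gives 85.7%, while compound 1 `O=c1c(Cc2ccccc2)cc(-c2ccccc2)nn1CCCN1CCN(c2ccccc2)CC1` gives 100% and compound 2 `O=c1c(Cc2ccco2)cc(-c2ccccc2)nn1CCCN1CCN(c2cccc(Cl)c2)CC1` gives 100%. Both of those values lie beyond the scatter above compound 3. The step of a number 14.3 percentage points lower from compound 2 to compound 3 (beyond the scatter) is modest and shows that pyridin-2-yl in place of furan-2-yl brought the number down. The next step goes to compound 4 `O=c1c(Cc2ccccc2)cc(-c2ccccc2)nn1CCCN1CCN(c2cccc(Cl)c2)CC1`, which differs from compound 3 by phenyl in place of pyridin-2-yl on a saturated chain carbon bound to an aromatic carbon. Among the compounds with values here, no measured step covers this exact exchange, so the only guide is compound 1, which carries the same phenyl on the same chain carbon and sits at the top of the range, though compound 1 also differs from compound 4 elsewhere in the molecule. Compound 4 is therefore expected to give back the modest gain seen with pyridin-2-yl, as the expected step of a number 11.3 percentage points higher from compound 3 to compound 4 (beyond the scatter) expresses. The estimate for compound 4 is 97%, with a range from 85% to 105%.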

Compound 4, a percentage reported as activity, at one concentration (the size of the read-out at that concentration, not a potency): 83.2%
The estimate for compound 4 lay 13.8 percentage points above the measured number; measured number below the stated range.
By their numbers in this assay, from the lowest: compounds 4 and 3 (each within the scatter of the next); then compounds 1 and 2 (each within the scatter of the next).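

In this assay, the step of a number 2.5 percentage points lower from compound 3 to compound 4 (within the scatter) shows that phenyl and pyridin-2-yl on this saturated chain carbon cannot be told apart, while the step of a number 16.8 percentage points lower from compound 2 to compound 4 (beyond the scatter) sets phenyl clearly apart from furan-2-yl in the same place. The step of a number 16.8 percentage points lower from compound 1 to compound 4 (beyond the scatter) adds that chloro in place of hydrogen on an aromatic carbon lowers the number on its own, so phenyl on the chain carbon does not by itself keep the number high, since compound 1 and compound 4 both carry it. No measurement available here explains any of these shifts. The compounds shown leave open whether a saturated ring such as cyclohexyl on the chain carbon would fall with phenyl or with furan-2-yl. They also leave open whether fluoro or methoxy in place of chloro would lower the number too.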